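The source may report more compounds than this note shows. Statements on the series, on what has been measured and on what is new or still open speak of the compounds shown alone.

Of the compounds shown here, two built on one shared core have been measured in a functional assay on KB cells (Homo sapiens) for inhibition; a higher number here means a weaker inhibitor, a lower number a stronger inhibitor. Compound 1 (`CC(=O)OC1C(CCl)OC(n2c(Cl)nc3cc(Cl)c(Cl)cc32)C1OC(C)=O`) carries chloro on a saturated chain carbon bound to a saturated ring carbon and gives 90000 nM. Compound 2 (`CC(=O)OC1C(CI)OC(n2c(Cl)nc3cc(Cl)c(Cl)cc32)C1OC(C)=O`) carries iodo at that place and gives 60000 nM. Going by the values given here, the only measured step is a 1.5-fold lower number from compound 1 to compound 2 (0.18 log units; within the scatter), so compound 2 stands level with compound 1 on these numbers.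

Compound 3 (`CC(=O)OC1C(CN=[N+]=[N-])OC(n2c(Cl)nc3cc(Cl)c(Cl)cc32)C1OC(C)=O`) takes compound 2 one exchange further: azido in place of iodo on a saturated chain carbon bound to a saturated ring carbon. This puts azido in place of iodo on the same saturated chain carbon. Among the compounds with values here, the one measured step at this place bears on the change, though it swaps one halogen for another, and no measured compound carries azido. That step, a 1.5-fold lower number from compound 1 to compound 2 (0.18 log units; within the scatter), gives no sign that exchange at this place shifts the number, so no step beyond the scatter is expected in this assay. The expected step is no change at the digits printed from compound 2 to compound 3 (within the scatter). For compound 3 the estimated value is 60000 nM, with an expected range of 25000 nM to 130000 nM.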

Compound 3, half-maximal inhibitory concentration: 70000 nM
Compound 3: middle estimate off by 1.2-fold (0.07 log units), on the low side, within the range that was stated.
By their numbers in this assay, from the lowest: compounds 2, 3 and 1 (each within the scatter of the next).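

Azido is the first group at this place that is not a halogen, and in this assay it leaves the number where the two halogens had it: azido in place of iodo gives a 1.2-fold higher number from compound 2 to compound 3 (0.07 log units; within the scatter) and azido in place of chloro gives a 1.3-fold lower number from compound 1 to compound 3 (0.11 log units; within the scatter). On a saturated chain carbon bound to a saturated ring carbon, chloro, iodo and azido therefore cannot be told apart on these numbers, even though azido brings 3 heavy atoms where iodo brings 1, and counts 1 hydrogen-bond acceptor where iodo counts 0. No supporting measurement is available that would explain this result.

The compounds shown leave open whether a group of another kind at this place, such as an amine, a carboxylic acid or a longer chain, would move the number beyond the scatter. They also leave open whether this lack of separation holds on other cores, since the rest of the shared core is the same in all three compounds.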